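This account rests on a few compounds, and the source may have more. Where it says the series, first, only, none or still open, it means among the compounds named here.

Of the compounds shown here, three built on one shared core have been tested in a functional assay on SW-620 cells (Homo sapiens) for inhibition, read by MTT assay, with a stated time of 72 h; a higher number here means a weaker inhibitor, a lower number a stronger inhibitor. Compound 1, `O=C1O[C@H]([C@@H](O)Cn2ccc(NC(=O)c3ccccc3)nc2=O)C(OCc2ccccc2)=C1OCc1ccccc1`, gives only a limit of the assay, > 100000 nM in this assay. Compound 2, `O=C1O/C(=C\Cn2c(=O)[nH]c(=O)[nH]c2=O)C(OCc2ccccc2)=C1OCc1ccccc1`, likewise gives only a limit, > 100000 nM. Compound 3, `NC1(CCn2ccc(=O)[nH]c2=O)OC(=O)C(OCc2ccccc2)=C1OCc1ccccc1`, also reaches no number and gives the limit > 100000 nM. On the numbers shown, compound 3 stands where the other two stand, at the limit of this assay, as summed up by the limit of > 100000 nM in this assay, at which 3 of the 3 values shown sit. The next compound, compound 4, `NC1(CCn2cc(F)c(=O)[nH]c2=O)OC(=O)C(OCc2ccccc2)=C1OCc1ccccc1`, differs from compound 3 in one place: fluoro in place of hydrogen on an aromatic carbon. Going by the values given here, no step between two measured compounds is available to calibrate what this change does in this assay. Given that every value so far is a limit, the expected step is a number no higher from compound 3 to compound 4 (the limit leaves the size open), none beyond the scatter, and another limit is the most likely outcome. Compound 4 is estimated at 100000 nM in this assay, within a range from 30000 nM to 300000 nM.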

Compound 4, half-maximal inhibitory concentration: > 100000 nM
Compound 4: only a limit was reported (the forecaster's own chance of this, stated with the estimate: 70%); the middle value sits exactly at the limit.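

Compound 3 and compound 4 both give only a limit in this assay, so the step for fluoro in place of hydrogen on an aromatic carbon cannot be read. The compounds shown leave open which change to the shared core, if any, would give a readable number: the limit of > 100000 nM in this assay, at which 4 of the 4 values shown sit.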